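The compounds below may be only part of what the source reports. "The series", "measured", "known", "first", "only" and "open" are said of these compounds alone.

Working notes on the series.

Going by the values given here, compound 1 `CC[C@@H](C)[C@H](NC(=O)c1cc(Cl)ccc1OCCNC(=O)OC(C)(C)C)C(=O)Nc1ccc([N+](=O)[O-])cc1Cl` is the one member with a numerical result: in a functional assay on MCF7 cells (Homo sapiens) for inhibition, read by MTT assay, with a stated time of 72 h (a higher number here means a weaker inhibitor, a lower number a stronger inhibitor), compound 1 gives 10500 nM. Compound 2 `CC[C@@H](C)[C@H](NC(=O)c1cc(Cl)ccc1OCCN)C(=O)Nc1ccc([N+](=O)[O-])cc1Cl` carries hydrogen in place of tert-butoxycarbonyl on an amine nitrogen. In this assay compound 2 reaches only a limit, > 10000 nM. The step that the limit leaves unreadable from compound 1 to compound 2 is therefore not readable in size, since (the limit of > 10000 nM in this assay, at which 2 of the 3 values shown sit).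

Compound 3 `CC(C)(C)OC[C@@H](NC(=O)c1cc(Cl)ccc1OCCNC(=O)OC(C)(C)C)C(=O)Nc1ccc([N+](=O)[O-])cc1Cl` has a different core; the difference between the two cores is not broken down here. In this assay compound 3 also gives only a limit, > 10000 nM.

Compound 4 `CC(C)(C)OC[C@@H](NC(=O)c1cc(Cl)ccc1OCCN)C(=O)Nc1ccc([N+](=O)[O-])cc1Cl` is the not yet measured partner of compound 3, differing by hydrogen in place of tert-butoxycarbonyl on an amine nitrogen, the same change as from compound 1 to compound 2. The step that the limit leaves unreadable from compound 3 to compound 4 is expected to stay small, because compound 3 already sits at > 10000 nM and the earlier step that the limit leaves unreadable from compound 1 to compound 2 left no readable shift. Compound 4 is estimated at 20000 nM, between 8000 nM and 60000 nM, most likely reported as a limit again.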

Compound 4, half-maximal inhibitory concentration: 1620 nM
Compound 4: middle estimate off by 12-fold (1.09 log units), on the high side; measured number below the stated range.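

In this assay, replacing tert-butoxycarbonyl with hydrogen on the amine nitrogen of the core of compound 3 gives an at least 6.1-fold lower number from compound 3 to compound 4 (0.79 log units; beyond the scatter), a step beyond the scatter. From the compounds shown here alone, compound 3 gives > 10000 nM, which is a limit, so the full size of this step stays unknown. The same change on the core of compound 1 cannot be read, and the series therefore does not show that the change carries from one core to the other: the limit of > 10000 nM in this assay, at which 2 of the 4 values shown sit.

The compounds shown leave open whether the lower number on the core of compound 3 requires the primary amine of the 2-aminoethyl group. A dimethylamine, a carboxylic acid or a longer chain at this place could test that.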